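Sulfonamide aryl variation in a chlorobenzoyl-piperidine series

The source may report more compounds than this note shows. Statements on the series, on what has been measured and on what is new or still open speak of the compounds shown alone.

Measured so far:
compound 1 `COc1cc(N)c(Cl)cc1C(=O)CCC1CCN(CCNS(=O)(=O)c2ccc(C)cc2)CC1` — 15%
compound 2 `COc1ccc(S(=O)(=O)CCCN2CCC(CCC(=O)c3cc(Cl)c(N)cc3OC)CC2)cc1` — 33%
compound 3 `COc1ccc(S(=O)(=O)NCCCN2CCC(CCC(=O)c3cc(Cl)c(N)cc3OC)CC2)cc1` — "not active" (no number reported)

In an assay on HEK293 cells for displacement of a labelled ligand from 5-hydroxytryptamine receptor 6 (Homo sapiens), with a stated time of 60 min, tested at 1 uM, in the presence of a further agent that is not named here (on this read-out lower numbers stand for a weaker effect and higher numbers for a stronger effect at the one concentration tested), compound 1 gives 15%, the lowest of the two numbers recorded. Compound 2 gives 33%, a number that lies beyond the scatter above compound 1. Compound 3 gives "not active" (no number reported) and carries no number, so it cannot be ordered against the other two.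

Compound 4 `COc1cc(N)c(Cl)cc1C(=O)CCC1CCN(CCNS(=O)(=O)c2ccc(NC(C)=O)cc2)CC1` keeps the shared core of compound 1 and differs in one place: acetamido in place of methyl on an aromatic carbon. Among the compounds with values here, no measured pair in this set differs in that one place, so there is no step of this kind to lean on. Given that compound 1 sits at 15% and the change concerns only the group on the sulfonamide aryl, the expectation is a step within the scatter, a number 1 percentage points lower from compound 1 to compound 4 (within the scatter), with no direction claimed. Compound 4 is therefore expected to give about 14%, in a range from 0% to 32%.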

Compound 4, a percentage reported as inhibition, at one concentration (the size of the read-out at that concentration, not a potency): 67%
Beside the measured number, compound 4's estimate is 53 percentage points below it; the measured number lies above the stated range.
By their numbers in this assay, from the lowest: compound 1; then compound 2; then compound 4.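

In this assay, replacing methyl with acetamido on the sulfonamide aryl gives a number 52 percentage points higher from compound 1 to compound 4 (beyond the scatter). Within the data shown here, this is the first step read across a single change, and it shows that the group on this aromatic carbon, para to a large group, can by itself move the read-out beyond the scatter while the rest of compound 1 stays fixed. Nothing available ties the step to any one feature of the acetamido group, which differs from methyl in its heavy atoms and in carrying a hydrogen-bond donor and acceptor.

Going by these compounds, whether the full acetamido group is needed remains open, as an amine or a methoxy group at the same place would test simpler replacements. Also open, on these data alone, is whether acetamido gives a similar step with a longer chain on the sulfonamide nitrogen.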